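The compounds below may be only part of what the source reports. "The series", "measured", "known", "first", "only" and "open" are said of these compounds alone.

compound 1 `Cn1c(-c2ccccc2)ccc1-c1ccc(C(=N)N)cc1`: 3800 nM
compound 2 `N=C(N)c1ccc(-c2ccc(-c3cccc([N+](=O)[O-])c3)o2)cc1`: 3300 nM
compound 3 `CC(C)(C)c1ccc(-c2ccc(-c3ccc(C(=N)N)cc3)o2)cc1`: 3800 nM

All three values come from a functional assay on MDA-MB-468 cells (Homo sapiens) for cytotoxicity, read by MTT assay, with a stated time of 96 h (a higher number here means a weaker inhibitor, a lower number a stronger inhibitor), a test of how strongly each compound harms cultured cells. Differences between repeated measurements in such a test are normal, so small gaps between numbers carry no meaning. Here, compound 2 at 3300 nM lies within the scatter of both compound 1 at 3800 nM and compound 3 at 3800 nM. On these numbers, it stands level with the other two.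

The next compound to be tested in this assay is compound 4 `N=C(N)c1ccc(-c2ccc(-c3cccc(F)c3)o2)cc1`, which has fluoro in place of nitro on an aromatic carbon of compound 2: fluoro in place of nitro on an aromatic carbon. For the measured compounds named here, no measured pair of compounds shows the effect of a single change like this one, so the data offer no direct guide. The only indirect clue is that compound 1 and compound 3 differ in structure from compound 2, yet all three values sit within the scatter of one another. A step beyond the scatter is therefore not expected, though the uncertainty is wide. The expected change is a 1.1-fold higher number from compound 2 to compound 4 (0.03 log units; within the scatter), an estimate that stays within the scatter. For compound 4 the estimated value is 3500 nM, with an expected range from 1400 nM to 8500 nM.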

Compound 4, half-maximal inhibitory concentration: 2400 nM
Compound 4: middle estimate off by 1.5-fold (0.16 log units), on the high side, and the stated range covers the measured number.
By their numbers in this assay, from the lowest: compounds 4, 2, 1 and 3 (each within the scatter of the next).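

In this assay, for the compounds shown here, fluoro in place of nitro on an aromatic carbon, meta to a large group, gives the first single-place comparison: a 1.4-fold lower number from compound 2 to compound 4 (0.14 log units; within the scatter). This position therefore accepts a large swap in the counted features without a step beyond the scatter, since nitro brings three heavy atoms and two hydrogen-bond acceptors, while fluoro brings one heavy atom and no acceptors. Nothing available explains this outcome or shows which feature of either group matters here, if any does.

As far as these compounds go, two groups at a single position give one step and cannot establish a trend, so it remains open whether an amine, a carboxylic acid or a methoxy group at the same place would read level with compound 2 and compound 4 or move clearly away from them. From the compounds shown here alone, it is also open whether the ring with only hydrogen at this position would give a similar number, which would help show whether a group here is needed at all.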